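A few compounds are considered here, and "the series" means these few. Any claim that something is new, unique, unknown or untested is made for them only; others in the source may bear on it.

Compound 1 `CCn1c(C(=O)NCC(=O)OC)ccc1C(CC)(CC)c1ccc(OCS(=O)(=O)c2ccccc2)c(C)c1`: 20000 nM
Compound 2 `CCn1c(C(=O)N[C@@H](CO)CCCO)ccc1C(CC)(CC)c1ccc(OCS(=O)(=O)c2ccccc2)c(C)c1`: 16400 nM
Compound 3 `CCn1c(C(=O)N[C@H](C(=O)O)C(C)C)ccc1C(CC)(CC)c1ccc(OCS(=O)(=O)c2ccccc2)c(C)c1`: 16200 nM

These values come from a functional assay on BXPC-3 cells (Homo sapiens) for antiproliferative activity, read by MTT assay, with a stated time of 24 h; on this read-out lower numbers stand for stronger inhibition and higher numbers for weaker inhibition. Compound 3 lies within the scatter of both other compounds, so the three cannot be ranked. Compound 4 `CCn1c(C(=O)NCCC(=O)O)ccc1C(CC)(CC)c1ccc(OCS(=O)(=O)c2ccccc2)c(C)c1` carries one change, 2-carboxyethyl in place of 1-carboxy-2-methylpropyl on an amide-type nitrogen. For the measured compounds named here, no measured step makes this exact exchange. The three steps at the same nitrogen are a 1.2-fold lower number from compound 1 to compound 2 (0.09 log units; within the scatter), a 1.2-fold lower number from compound 1 to compound 3 (0.09 log units; within the scatter) and a 1.0-fold lower number from compound 2 to compound 3 (0.01 log units; within the scatter), and all stay within the scatter. In this assay, the author therefore expects no shift beyond the scatter. The expected result is a 1.0-fold higher number from compound 3 to compound 4 (0.02 log units; within the scatter). For compound 4, the estimated value is 17000 nM, with an expected range from 9000 nM to 30000 nM.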

Compound 4, half-maximal inhibitory concentration: > 50000 nM
Compound 4: no number, only a limit (the forecaster's own chance of this, stated with the estimate: 15%); middle value at least 2.9-fold (0.46 log units) from the limit.
By their numbers in this assay, from the lowest: compounds 3, 2 and 1 (each within the scatter of the next). At a limit, above all of these: compound 4.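

In this assay, compound 4 gives only a limit of the assay: the limit of > 50000 nM in this assay, at which 1 of the 4 values shown sits.

Substituents on the amide-type nitrogen had so far stayed within the scatter of one another, but this position is not indifferent to every change. The 2-carboxyethyl group gives an at least 3.0-fold higher number from compound 3 to compound 4 (0.48 log units; beyond the scatter), alongside an at least 3.0-fold higher number from compound 2 to compound 4 (0.48 log units; beyond the scatter) and an at least 2.5-fold higher number from compound 1 to compound 4 (0.39 log units; beyond the scatter).

The compounds shown do not separate the removal of the branch and defined stereocentre of 1-carboxy-2-methylpropyl from the shortening of the chain, and the limit leaves the full size of these steps open. As far as these compounds go, how an amine or a longer carboxylic acid chain on this nitrogen would read also remains open.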